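This account rests on a few compounds, and the source may have more. Where it says the series, first, only, none or still open, it means among the compounds named here.

Compound 1 `CN(Cc1ccccc1F)C(=O)CNC(=O)c1ccc(S(C)(=O)=O)c([N+](=O)[O-])c1` gives 11400 nM in an ADME assay on HepG2 cells (Homo sapiens) for cytotoxicity, read by CellTiter-Glo and ATP content, with a stated time of 72 h; a lower number here means that less compound is needed, a higher number that more compound is needed for the effect. Compound 2 `CN(Cc1ccccc1)C(=O)CNC(=O)c1ccc(S(C)(=O)=O)c([N+](=O)[O-])c1` gives only a limit, > 27000 nM, in this assay.

Compound 2 thus stands at the limit, (the limit of > 27000 nM in this assay, at which 1 of the 2 values shown sits), and its number is not known. Compound 3 `CN(Cc1cccc(F)c1)C(=O)CNC(=O)c1ccc(S(C)(=O)=O)c([N+](=O)[O-])c1` differs from compound 2 by fluoro in place of hydrogen on an aromatic carbon. Within the data shown here, the one measured step, an at least 2.3-fold higher number from compound 1 to compound 2 (0.37 log units; beyond the scatter), went the other way, with a fluoro leaving and the limit reached. A fluoro entering, though at a different place, is therefore expected to lower the number in this assay. The estimate for compound 3 is 18000 nM, between 7000 nM and 45000 nM, an expected step of an at least 1.5-fold lower number from compound 2 to compound 3 (0.17 log units; that floor lies within the scatter).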

Compound 3, half-maximal effective concentration: > 27000 nM
Compound 3 ended at the assay's limit; the forecaster's own chance of this, stated with the estimate: 40%; middle value at least 1.5-fold (0.17 log units) away from the limit.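

Replacing 2-fluorophenyl with 3-fluorophenyl gives an at least 2.3-fold higher number from compound 1 to compound 3 (0.37 log units; beyond the scatter) in this assay, so a fluoro on this ring does not by itself bring the number below the limit; among the compounds shown, only the 2-fluorophenyl of compound 1 gives a measured number. Compound 2 and compound 3 both stand at a limit, and the step between them cannot be read: the limit of > 27000 nM in this assay, at which 2 of the 3 values shown sit.

Going by these compounds, how far the true numbers of compound 2 and compound 3 lie beyond that limit remains open. So does whether a chloro or a methoxy group in place of the fluoro of compound 1 would also give a measurable number.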